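This account rests on a few compounds, and the source may have more. Where it says the series, first, only, none or still open, it means among the compounds named here.

Measured so far:
- Compound 1 `CN(C)CCCCCn1c2c(c3ccccc31)C(=O)c1c[n+]([O-])c3ccccc3c1C2=O`: 240 nM
- Compound 2 `O=C1c2c[n+]([O-])c3ccccc3c2C(=O)c2c1c1ccccc1n2Cc1cn(C[C@H](O)CO)nn1`: 1130 nM

Both values come from a toxicity assay on L02 cells (Homo sapiens) for cytotoxicity, read by MTT assay, with a stated time of 72 h; a higher number here means a weaker inhibitor, a lower number a stronger inhibitor. Compound 2 has the higher of the two numbers. Compound 3 `CC1(C)OC[C@@H](Cn2cc(Cn3c4c(c5ccccc53)C(=O)c3c[n+]([O-])c5ccccc5c3C4=O)nn2)O1` differs from it as follows: 2,2-dimethyl-1,3-dioxolan-4-yl in place of 1,2-dihydroxyethyl on a saturated chain carbon bound to an aromatic nitrogen. Within the data shown here, only one measured step bears on this change, a 4.7-fold higher number from compound 1 to compound 2 (0.67 log units; beyond the scatter). That modest step involved a different exchange, so it offers only a rough guide to size. A step of similar or smaller size is expected, towards a lower number. The expected change is a 1.6-fold lower number from compound 2 to compound 3 (0.21 log units; within the scatter). For compound 3 the estimated value is 700 nM, with an expected range from 300 nM to 1600 nM.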

Compound 3, half-maximal inhibitory concentration: 2900 nM
The estimate for compound 3 lay 4.1-fold (0.62 log units) below the measured number, and the stated range ends below it.
By their numbers in this assay, from the lowest: compound 1; then compound 2; then compound 3.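

In this assay, closing the diol into 2,2-dimethyl-1,3-dioxolan-4-yl gives a 2.6-fold higher number from compound 2 to compound 3 (0.41 log units; beyond the scatter) and so runs against the expected fall. Where the earlier step exchanged the whole side chain, this one shows that a change confined to the end of the triazole-bearing chain is enough to move the number beyond the scatter. Nothing available explains the step.

The compounds shown do not separate the loss of the two hydroxyl groups from the gain of the ring and its two methyl groups. As far as these compounds go, how an amine or a carboxylic acid would fare in this place also remains open.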